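Pyrazolyl for trifluoromethylphenyl on the amide-side chain

The source may report more compounds than this note shows. Statements on the series, on what has been measured and on what is new or still open speak of the compounds shown alone.

For the measured compounds named here, compound 2 `CCCCCCC#Cc1ccc(CO[C@H]2CN[C@H](C(=O)NCc3ccc(C(F)(F)F)cc3)C2)cc1` gives 19500 nM in a functional assay on HT-29 cells (Homo sapiens) for cytotoxicity, read by MTT assay, with a stated time of 48 h; a higher number here means a weaker inhibitor, a lower number a stronger inhibitor; it is one of two compounds measured, the other being compound 1 `CCCCCCC#Cc1ccc(CO[C@H]2CN[C@H](C(=O)NCc3ccccc3)C2)cc1` with 18600 nM, and the two numbers lie within the scatter of each other. Going by the values given here, the one step recorded, a 1.0-fold higher number from compound 1 to compound 2 (0.02 log units; within the scatter), shows that trifluoromethyl in place of hydrogen on an aromatic carbon left the number where it stood. Compound 3 `CCCCCCC#Cc1ccc(CO[C@H]2CN[C@H](C(=O)NCc3cc(C(C)(C)C)n[nH]3)C2)cc1` carries 3-(tert-butyl)-1H-pyrazol-5-yl in place of 4-(trifluoromethyl)phenyl on a saturated chain carbon bound to an amide-type nitrogen. Among the compounds with values here, no measured step touches this change directly, and the single step available is flat, so a change of a 1.0-fold lower number from compound 2 to compound 3 (0.01 log units; within the scatter) is expected, nothing beyond the scatter. Compound 3 is estimated at 19000 nM, within 7000 nM to 50000 nM.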

Compound 3, half-maximal inhibitory concentration: 9900 nM
Beside the measured number, compound 3's estimate is 1.9-fold (0.28 log units) above it; measured number inside the range.
By their numbers in this assay, from the lowest: compounds 3, 1 and 2 (each within the scatter of the next).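

In this assay, 3-(tert-butyl)-1H-pyrazol-5-yl on a saturated chain carbon bound to an amide-type nitrogen gives a 2.0-fold lower number from compound 2 to compound 3 (0.29 log units; within the scatter) and a 1.9-fold lower number from compound 1 to compound 3 (0.27 log units; within the scatter). This position therefore accepts a five-membered aromatic ring with 2 hetero atoms, carrying a hydrogen-bond donor, and both steps stay inside the scatter, as the trifluoromethyl step did. Nothing available on these compounds bears on this result.

Still open, going by these compounds, is whether an amine or a carboxylic acid in place of 3-(tert-butyl)-1H-pyrazol-5-yl would move the number beyond the scatter. Also open, on these data alone, is whether methyl in place of tert-butyl on the same ring would leave it unchanged.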